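The source may report more compounds than this note shows. Statements on the series, on what has been measured and on what is new or still open speak of the compounds shown alone.

Measured in a functional assay on MDA-MB-231 cells (Homo sapiens) for cytotoxicity, read by MTT assay, with a stated time of 48 h (on this read-out higher numbers stand for weaker inhibition and lower numbers for stronger inhibition), so far:
compound 1 `COc1cc(/C=C2\C(=O)Nc3ccc(Cl)cc32)ccc1OCCCN1CC(C)OC(C)C1` gives 1990 nM
compound 2 `COc1cc(/C=C2\C(=O)Nc3ccc(C)cc32)ccc1OCCCN1CC(C)OC(C)C1` gives 11500 nM
compound 3 `COc1cc(/C=C2\C(=O)Nc3ccc(Cl)cc32)ccc1OCCCN1CCN(c2ncccc2C(F)(F)F)CC1` gives 1260 nM

Compound 1 and compound 2 share one core and differ only by methyl in place of chloro on an aromatic carbon. That single change produced a 5.8-fold higher number from compound 1 to compound 2 (0.76 log units; beyond the scatter). Compound 3 carries a different amine end; how the core of compound 3 differs from the core of compound 1 is not broken down here. Compound 3 holds the lowest number of the three, but compound 1 lies within the scatter of it, so no order between those two can be read. The gap between compound 3 and compound 2 lies beyond the scatter.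

Compound 4 `COc1cc(/C=C2\C(=O)Nc3ccc(C)cc32)ccc1OCCCN1CCN(c2ncccc2C(F)(F)F)CC1` is to be measured in this assay. It differs from compound 3 by methyl in place of chloro on an aromatic carbon, the same change already seen from compound 1 to compound 2, at a place described in the same words. For the measured compounds named here, with only that one earlier pair to rest on, a step of comparable size is expected from compound 3 to compound 4 in this assay, namely a 5.6-fold higher number from compound 3 to compound 4 (0.74 log units; beyond the scatter), because of a 5.8-fold higher number from compound 1 to compound 2 (0.76 log units; beyond the scatter). Going by the values given here, the estimate for compound 4 is therefore 7000 nM, with a range from 2500 nM to 20000 nM allowing for the scatter and for the single precedent.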

Compound 4, half-maximal inhibitory concentration: > 20000 nM
Compound 4 ended at the assay's limit; the forecaster's own chance of this, stated with the estimate: 10%; middle value at least 2.8-fold (0.45 log units) from the limit.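

In this assay, methyl in place of chloro on an aromatic carbon again moves the number upward, with an at least 15-fold higher number from compound 3 to compound 4 (1.20 log units; beyond the scatter). Compound 4 stands at a limit of this assay and not at a number, so this step has a lower bound but no measured size: the limit of > 20000 nM in this assay, at which 1 of the 4 values shown sits. The direction of the change carries over from the core of compound 1 to the core of compound 3, but its size does not carry over as one fixed step, and two pairs give neither a general rule for the series nor a reason for the gap: the same change on two cores in this assay, a 5.8-fold higher number (0.76 log units; beyond the scatter) from compound 1 to compound 2 and an at least 15-fold higher number (1.20 log units; beyond the scatter) from compound 3 to compound 4, at least 2.7-fold (0.43 log units) apart, beyond the scatter of two such steps.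

From the compounds shown here alone, it remains open whether fluoro, bromo or nitrile on the same aromatic carbon would fall with chloro or with methyl in this assay. Going by these compounds, it is also open whether the change would give a step of either size with a primary amine end or with a longer chain leading to the amine.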